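Aryl substituent swaps on a quinone sulfonylamidine series

The compounds below may be only part of what the source reports. "The series", "measured", "known", "first", "only" and "open" are said of these compounds alone.

Compound 1, `Cc1ccc(S(=O)(=O)/N=C(/CCNC2=CC(=O)c3ccccc3C2=O)Nc2ccc(Cl)cc2)cc1`, gives 65400 nM in an ADME assay on HEK293 cells (Homo sapiens) for cytotoxicity, read by MTT assay, with a stated time of 48 h; on this read-out lower numbers stand for stronger inhibition and higher numbers for weaker inhibition.
Compound 2, `Cc1ccc(S(=O)(=O)/N=C(/CCNC2=CC(=O)c3ccccc3C2=O)Nc2ccc(F)cc2)cc1`, gives 55100 nM in this assay.
Compound 3, `Cc1ccc(S(=O)(=O)/N=C(/CCNC2=CC(=O)c3ccccc3C2=O)Nc2cccc(C)c2)cc1`, gives 56200 nM in this assay.

The three measured compounds share one core and differ only in the aryl group on the amine nitrogen. Their numbers in this assay lie close together: the step of a 1.2-fold lower number from compound 1 to compound 2 (0.07 log units; within the scatter), the step of a 1.2-fold lower number from compound 1 to compound 3 (0.07 log units; within the scatter) and the step of a 1.0-fold higher number from compound 2 to compound 3 (0.01 log units; within the scatter) all sit within the scatter, so none of the three can be set apart from the others. Compound 3 stands second highest of the three, but its distance to compound 2 and to compound 1 is each within the scatter.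

Compound 4, `Cc1ccc(S(=O)(=O)/N=C(/CCNC2=CC(=O)c3ccccc3C2=O)Nc2cccc(C(F)(F)F)c2)cc1`, carries the change (trifluoromethyl in place of methyl on an aromatic carbon). Within the data shown here, no measured step alters the group at that position; the nearest comparisons are the aryl swaps above, which moved the numbers by amounts within the scatter. On that basis compound 4 is expected to show a step of a 1.0-fold lower number from compound 3 to compound 4 (0.01 log units; within the scatter), that is, no shift beyond the scatter. The estimate for compound 4 in this assay is 55000 nM, with a range from 25000 nM to 120000 nM.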

Compound 4, half-maximal inhibitory concentration: 91500 nM
Compound 4: the middle estimate sits 1.7-fold (0.22 log units) below what was measured; the range from low to high includes it.
By their numbers in this assay, from the lowest: compounds 2, 3, 1 and 4 (each within the scatter of the next).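

At this position, meta to a large group, methyl gives way to trifluoromethyl, which takes the group from 1 heavy atom to 4 and is the only step shown that alters the substituent itself rather than swapping the whole aryl group. In this assay that change gives a 1.6-fold higher number from compound 3 to compound 4 (0.21 log units; within the scatter), so this position tolerates the larger group without a shift that can be told apart from repeat measurements, and the comparisons with the para-free halogen series do not alter this: the aryl swaps read a 1.7-fold higher number from compound 2 to compound 4 (0.22 log units; within the scatter) and a 1.4-fold higher number from compound 1 to compound 4 (0.15 log units; within the scatter). Nothing in the data explains the size of these steps.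

As far as these compounds go, whether a hydrogen, an amine or a carboxylic acid on this same aromatic carbon would give a step beyond the scatter remains open. From the compounds shown here alone, it is also open whether any change to the aryl group on the amine nitrogen can move this cytotoxicity read-out clearly, since all four compounds still lie within the scatter of their neighbours.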